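Inverting One Ring Stereocentre in a Lipid-Like Receptor Agonist

The source may hold more compounds than are shown below. What is called first, only, known or untested is meant among the compounds shown, and "the series" means these compounds.

Compound 1 `CCCCCCCCCCCOc1ccccc1CCC(=O)OCc1ccccc1OP(=O)(O)OC[C@H](N)C(=O)O`: in an assay on HEK293-A cells with probable G-protein coupled receptor 34 (Mus musculus) as the target, with a stated time of 1.5 h (a lower number here means a smaller maximal response, a higher number a larger maximal response), compound 1 gives 0.2.
Compound 2 `CCCCCCCCCCCOc1ccccc1CCC(=O)OC[C@H]1OCC=C[C@H]1OP(=O)(O)OC[C@H](N)C(=O)O`: in this assay compound 2 gives 0.086.

Of the two measured compounds, compound 2 stands lowest in this assay; compound 1 sits higher, and that gap is wider than the usual scatter. For the measured compounds named here, no single-change step between the two measured compounds is available, so nothing measured ties one structural alteration to one shift in response.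

Compound 3 `CCCCCCCCCCCOc1ccccc1CCC(=O)OC[C@H]1OCC=C[C@@H]1OP(=O)(O)OC[C@H](N)C(=O)O` has not yet been measured. It differs from compound 2 only in configuration: the two compounds have the same atoms and bonds; at least one stereo element is drawn with a configuration in one of them and without one in the other: 1 of 4 stereo elements differ; a stereocentre at a saturated ring carbon is drawn R in compound 2 and S in compound 3. Going by the values given here, the data hold no example of such an inversion at the ring carbon, so its direction cannot be read from what is measured; a step in either direction, or none beyond the scatter, is possible. The step a number 0.034 higher from compound 2 to compound 3 (within the scatter) is expected to be small and upward. Compound 3 is expected to reach about 0.12, with a likely range from 0.04 to 0.3.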

Compound 3, intrinsic activity: the largest response reached, as a fraction of the reference agonist's: "not active" (no number reported)
The entry for compound 3 holds no number; no gap can be computed for the estimate.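

In this assay, for the compounds shown here, compound 3 is recorded as "not active" without a number, so no step from compound 2 can be read. How far the inverted ring carbon alone changes the response stays open, and the comparison carries this caution: the fact that one of compounds 2 and 3 is drawn with a defined configuration and the other without, at the place where they differ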